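This account rests on a few compounds, and the source may have more. Where it says the series, first, only, none or still open, it means among the compounds named here.

Compound 1 `Cn1c(Cc2ccccc2)nc(C(=O)NCc2ccccc2)c(O)c1=O`: > 100000 nM, a limit
Compound 2 `Cn1c(Cc2ccccc2C(F)(F)F)nc(C(=O)NCC2CCCCC2)c(O)c1=O`: > 100000 nM, a limit

In an ADME assay on HepG2 cells (Homo sapiens) for cytotoxicity, in the presence of a further agent that is not named here (on this read-out higher numbers stand for weaker inhibition and lower numbers for stronger inhibition), compound 2 stands at > 100000 nM, which is a limit and not a number. Among the measured compounds shown here, the series so far shows one picture: the limit of > 100000 nM in this assay, at which 2 of the 2 values shown sit. Compound 3 `Cn1c(Cc2ccccc2C(F)(F)F)nc(C(=O)CCc2ccccc2)c(O)c1=O` carries phenethyl in place of (cyclohexylmethyl)amino on a carbonyl carbon, (phenethyl in place of (cyclohexylmethyl)amino on a carbonyl carbon). For the measured compounds named here, no step between measured compounds is available to size such a change, and neither compound so far gives a number. In this assay no shift beyond the usual scatter is expected, and the estimated change is a number no higher from compound 2 to compound 3 (the limit leaves the size open). This expectation rests on compound 2 and its limit of > 100000 nM. For compound 3 the expected value is 100000 nM, with an estimated range from 30000 nM to 200000 nM, and a report as a limit again is the likeliest outcome.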

Compound 3, half-maximal inhibitory concentration: > 100000 nM
Compound 3 gave a limit, no number; the forecaster's own chance of this, stated with the estimate: 80%; the middle value sits exactly at the limit.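

In this assay compound 2 and compound 3 are both reported as limits, not numbers, so the step between them cannot be read. The compounds shown leave open whether any change on the carbonyl carbon would give a measurable value in this assay at all.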